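The source may hold more compounds than are shown below. What is called first, only, known or untested is meant among the compounds shown, and "the series" means these compounds.

Three close relatives of compound 4 have already been measured in an ADME assay for metabolic stability, read by HPLC, in simulated gastric fluid, with a stated time of 12 h, at pH 1.2; a lower number here means that the compound disappears faster, a higher number that the compound lasts longer. Compound 1 `O=C(O)[C@@H](CO)NC(=O)[C@H]1C[C@@H](O)CN1` gives > 12 h, which is a limit of the measurement and not a number. Compound 2 `O=C(O)[C@@H](CO)NC(=O)[C@H]1C[C@H](O)CN1` likewise gives > 12 h, again a limit. Compound 3 `O=C(N[C@H](CO)C(=O)O)[C@@H]1C[C@H](O)CN1` also gives > 12 h, once more a limit. Because all three sit at the same limit (the limit of > 12 h in this assay, at which 3 of the 3 values shown sit), the steps between them, a step that the two limits leave unreadable from compound 1 to compound 2, a step that the two limits leave unreadable from compound 1 to compound 3 and a step that the two limits leave unreadable from compound 2 to compound 3, cannot be read in size; each of these pairs differs only in configuration as drawn (the fact that compounds 1 and 2 differ only in the configuration as drawn, (the fact that compounds 1 and 3 differ only in the configuration as drawn), (the fact that compounds 2 and 3 differ only in the configuration as drawn)). Compound 2 therefore stands at the limit, and nothing in the numbers sets it apart from compound 1 or compound 3.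

Compound 4 `O=C(O)[C@H](CO)NC(=O)[C@@H]1C[C@@H](O)CN1` differs from compound 2 as follows: the two compounds have the same atoms and bonds and differ only in configuration as drawn: 3 of 3 stereo elements differ (all stereocentres are inverted: mirror images); a stereocentre at a saturated chain carbon is drawn R in compound 2 and S in compound 4; a stereocentre at a saturated ring carbon is drawn R in compound 2 and S in compound 4; a stereocentre at a saturated ring carbon is drawn S in compound 2 and R in compound 4. The measured steps that bear on this change are all changes of configuration alone, and none of them gave a readable size. The expected step of a number no higher from compound 2 to compound 4 (the limit leaves the size open) is therefore none beyond the scatter. Compound 4 is expected to give 12 h in this assay, estimated between 8 h and 12 h, most likely reported again only as a limit.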

Compound 4, half-life: > 12 h
Compound 4 gave a limit, no number; the forecaster's own chance of this, stated with the estimate: 90%; the middle value lies on the limit itself.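

In this assay compound 4 gives > 12 h, which is a limit and not a number. Among these compounds, compound 1, compound 2 and compound 3 sit at the same limit, so no step from any of them to compound 4 can be read in size. The compounds shown leave open how long each actually lasts, and whether configuration as drawn makes any difference.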